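A few compounds are considered here, and "the series" means these few. Any claim that something is new, unique, unknown or untested is made for them only; others in the source may bear on it.

Compound 1 `CCc1c(C(C)c2c(F)cccc2Cl)nc(SC(C)C)[nH]c1=O`: > 3000 nM (a limit)
Compound 2 `CCCSc1nc(C(C)c2c(F)cccc2Cl)c(CC)c(=O)[nH]1`: > 3000 nM (a limit)

Both results come from an ADME assay on MT4 cells (Homo sapiens) for activation, read by MTT assay; on this read-out higher numbers stand for lower toxicity in this test and lower numbers for higher toxicity in this test. Compound 1 has no exact number here, only the limit > 3000 nM, and the one other result is a limit too: the limit of > 3000 nM in this assay, at which 2 of the 2 values shown sit. Among the compounds with values here, the only measured step is a step that the two limits leave unreadable from compound 1 to compound 2, so it offers no size to carry over.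

Compound 3 `CCc1c(C(C)c2c(F)cccc2F)nc(SC(C)C)[nH]c1=O` differs from compound 1 in a single place: fluoro in place of chloro on an aromatic carbon. This is fluoro in place of chloro on an aromatic carbon. Within the data shown here, no measured step covers this exchange, so no step beyond the usual scatter, and no direction, can be expected from the data. The expected change is a step that the limit leaves unreadable from compound 1 to compound 3. This expectation rests on compound 1 and its limit of > 3000 nM. Compound 3 is estimated at 5000 nM, with an expected range from 2500 nM to 30000 nM.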

Compound 3, half-maximal cytotoxic concentration: > 3000 nM
Compound 3 gave a limit, no number; the forecaster's own chance of this, stated with the estimate: 70%; the middle value lies beyond the limit too.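

Compound 3 gives only a limit, as compound 1 does, so no step in size can be read between compound 1 and compound 3, or between any of the compounds shown: the limit of > 3000 nM in this assay, at which 3 of the 3 values shown sit.

What the compounds shown leave open is how far fluoro in place of chloro, or propyl in place of isopropyl, moves the toxicity in this assay, if it moves it at all.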